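A few compounds are considered here, and "the series" means these few. Any claim that something is new, unique, unknown or untested is made for them only; others in the source may bear on it.

Measured so far:
compound 1 `COC(=O)Cn1nc2c(n1)C(=O)C(C)=C(C)C2=O`, 1 ug/mL
compound 2 `CC1=CC(=O)c2nn(C)nc2C1=O`, 0.3 ug/mL

Both were tested in a functional assay on HeLa cells (Homo sapiens) for inhibition, read by colorimetric assay, with a stated time of 72 h; a lower number here means that less compound is needed, a higher number that more compound is needed for the effect. Compound 1 gives 1 ug/mL, and compound 2 gives 0.3 ug/mL, the lower of the two numbers; the gap between them is beyond the usual scatter, so compound 2 needs less material for the same effect. For the measured compounds named here, no pair of measured compounds differs in only one place, so the size of any single change is not known directly.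

Compound 3 `COC(=O)Cn1nc2c(n1)C(=O)C(C)=CC2=O` is not yet measured. It is compound 2 with methoxycarbonyl in place of hydrogen on a saturated chain carbon bound to an aromatic nitrogen. Compound 1 carries the same chain and gives the higher number, but it also differs from compound 2 elsewhere, so that gap cannot be assigned to the chain alone. In this assay a step of modest size toward a higher number is expected, a 2.0-fold higher number from compound 2 to compound 3 (0.30 log units; within the scatter). Compound 3 is estimated at 0.6 ug/mL, with a range from 0.2 ug/mL to 2 ug/mL.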

Compound 3, concentration for half-maximal effect: 0.5 ug/mL
For compound 3 the middle estimate is 1.2-fold (0.08 log units) above the measured one; the measured number falls inside the stated range.
By their numbers in this assay, from the lowest: compounds 2, 3 and 1 (each within the scatter of the next, the first and the last beyond it).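

In this assay, methoxycarbonyl in place of hydrogen on a saturated chain carbon bound to an aromatic nitrogen gives a 1.7-fold higher number from compound 2 to compound 3 (0.22 log units; within the scatter), so this change can now be read on its own, and its size stays within the usual scatter of repeated measurements. Hydrogen in place of methyl on a double-bonded ring carbon gives a 2.0-fold lower number from compound 1 to compound 3 (0.30 log units; within the scatter), also within the scatter, so the gap beyond the scatter that separates compound 1 and compound 2 now resolves into two single changes, neither of which stands clear of the scatter alone. Nothing available explains either step.

Going by these compounds, it remains open whether an amine, a carboxylic acid or a longer chain on that chain carbon would give a step beyond the scatter. The compounds shown also leave open how chlorine in place of the ring methyl would read.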